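Thiophen-3-yl in place of 2-chlorophenyl

This account rests on a few compounds, and the source may have more. Where it says the series, first, only, none or still open, it means among the compounds named here.

Compound 1 `COc1cc(C(=O)c2sc(-c3ccc([N+](=O)[O-])cc3)cc2N)cc(OC)c1OC`: 99 nM
Compound 2 `COc1cc(C(=O)c2sc(-c3ccccc3Cl)cc2N)cc(OC)c1OC`: 16 nM

In a functional assay on CCRF-CEM cells (Homo sapiens) for antiproliferative activity (a lower number here means a stronger inhibitor, a higher number a weaker inhibitor), compound 2 holds the lower of the two numbers, at 16 nM. Compound 3 `COc1cc(C(=O)c2sc(-c3ccsc3)cc2N)cc(OC)c1OC` differs from compound 2 in one place: thiophen-3-yl in place of 2-chlorophenyl on an aromatic carbon. Within the data shown here, one measured step bears on that place, a modest one beyond the scatter, with 2-chlorophenyl in place of 4-nitrophenyl: a 6.2-fold lower number from compound 1 to compound 2 (0.79 log units; beyond the scatter). Among the measured compounds shown here, no thiophen-3-yl compound has been measured, so the direction is uncertain. Given that step, a modest rise in the number is expected in this assay. The estimated step is a 2.5-fold higher number from compound 2 to compound 3 (0.40 log units; beyond the scatter). For compound 3 the estimated value is 40 nM, within a range of 12 nM to 130 nM.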

Compound 3, half-maximal inhibitory concentration: 9.6 nM
Compound 3: middle estimate off by 4.2-fold (0.62 log units), on the high side; measured number outside the range, below it.
By their numbers in this assay, from the lowest: compounds 3 and 2 (each within the scatter of the next); then compound 1.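

In this assay thiophen-3-yl matches 2-chlorophenyl on this aromatic carbon, with a 1.7-fold lower number from compound 2 to compound 3 (0.22 log units; within the scatter) as the step, so a five-membered aromatic ring with a sulfur serves here as well as a six-membered aromatic ring of carbon only. Among these compounds, replacing 4-nitrophenyl with thiophen-3-yl gives a 10-fold lower number from compound 1 to compound 3 (1.01 log units; beyond the scatter) as the largest step at this place so far. No evidence at hand accounts for either step.

Thiophen-2-yl and furan-3-yl remain open at this place. So do non-aromatic groups such as morpholine or a plain methyl.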